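The compounds below may be only part of what the source reports. "The series", "measured", "known", "first", "only" and "open" are said of these compounds alone.

Of the compounds shown here, three share one core and have been measured in a functional assay on NCI-H460 cells (Homo sapiens) for inhibition, read by CCK-8 assay, with a stated time of 48 h; on this read-out higher numbers stand for weaker inhibition and lower numbers for stronger inhibition. Compound 1 is `Cc1ccc(-c2nn(-c3ccccc3)cc2C(=O)NC(=S)Nc2ccc(Cl)cc2)cc1` and in this assay gives 3650 nM. Compound 2 is `O=C(NC(=S)Nc1ccc(F)cc1)c1cn(-c2ccccc2)nc1-c1ccccc1` and in this assay gives 4210 nM. Compound 3 is `COc1ccc(NC(=S)NC(=O)c2cn(-c3ccccc3)nc2-c2ccc(OC)cc2)cc1` and in this assay gives 2570 nM. Compound 3 carries the lowest of the three numbers, but its gap to compound 1 and its gap to compound 2 both lie within the usual scatter of this measurement, so the three compounds cannot be told apart on these data.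

The next compound to be measured is compound 4, `COc1ccc(-c2nn(-c3ccccc3)cc2C(=O)NC(=S)Nc2ccc(F)cc2)cc1`. It differs from compound 3 in one place: fluoro in place of methoxy on an aromatic carbon. For the measured compounds named here, no pair among the measured compounds differs in exactly this way, so there is no measured step to lean on. The same fluoro already appears in compound 2, whose value sits within the scatter of compound 3, which gives no sign that this exchange moves the number. The expected step from compound 3 to compound 4 is therefore a 1.2-fold higher number from compound 3 to compound 4 (0.10 log units; within the scatter), none beyond the scatter. Compound 4 is estimated to give 3200 nM in this assay, expected to fall between 1600 nM and 6500 nM.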

Compound 4, half-maximal inhibitory concentration: 3050 nM
Compound 4: middle estimate off by 1.0-fold (0.02 log units), on the high side; low and high end bracket the measured number.
By their numbers in this assay, from the lowest: compounds 3, 4, 1 and 2 (each within the scatter of the next).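

In this assay, for the compounds shown here, the change from (4-methoxyphenyl)amino to (4-fluorophenyl)amino gives a 1.2-fold higher number from compound 3 to compound 4 (0.07 log units; within the scatter) and is the only measured exchange of methoxy for fluoro at this position, so the two groups cannot be told apart here. Compound 4 also completes a second single-place comparison, in which methoxy replaces hydrogen on an aromatic carbon elsewhere in the molecule: this gives a 1.4-fold lower number from compound 2 to compound 4 (0.14 log units; within the scatter) and likewise shows no readable change. No measurement is available that could explain either result.

As far as these compounds go, all the groups compared at these two places so far leave the numbers within the usual scatter, so it remains open whether this position responds to its substituent at all. An amine, a carboxylic acid or a longer chain in place of the fluoro would test that question, and a clear move in either direction would show that the position matters for inhibition in these cells.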